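Compound 4: (tert-butyl)amino in place of methyl

This account rests on a few compounds, and the source may have more. Where it says the series, first, only, none or still open, it means among the compounds named here.

In a functional assay on K562 cells (Homo sapiens) for antiproliferative activity, read by MTT assay, with a stated time of 48 h (on this read-out lower numbers stand for stronger inhibition and higher numbers for weaker inhibition), compound 1 `COC(=O)[C@H](CC(C)C)NC(=O)c1ccc(Oc2nc3ccccc3nc2C)cc1` gives 22600 nM, compound 2 `COC(=O)[C@H](CC(C)C)NC(=O)c1ccc(Oc2nc3cc(Cl)ccc3nc2C)cc1` gives 22000 nM and compound 3 `CC[C@@H](C)[C@H](NC(=O)c1ccc(Oc2nc3ccccc3nc2C)cc1)C(=O)O` gives 30500 nM. Compound 1 therefore stands in a tight group, within the scatter of both other compounds, with no order to read among the three.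

Compound 4 `COC(=O)[C@H](CC(C)C)NC(=O)c1ccc(Oc2nc3ccccc3nc2NC(C)(C)C)cc1` keeps the core and the amide side chain of compound 1 and changes one place, with (tert-butyl)amino in place of methyl on an aromatic carbon.

Going by the values given here, two measured steps bear on this only indirectly. Chloro in place of hydrogen on an aromatic carbon gave a 1.0-fold lower number from compound 1 to compound 2 (0.01 log units; within the scatter). The exchange of the substituent on the amide-type nitrogen gave a 1.3-fold higher number from compound 1 to compound 3 (0.13 log units; within the scatter). Among the compounds with values here, both are within the scatter, and neither touches the methyl, so the data hold no direct precedent for this change and no direction for it. A small step is expected, with a tentative lean towards a lower number and wide uncertainty, and it is estimated as a 1.9-fold lower number from compound 1 to compound 4 (0.27 log units; within the scatter). For compound 4 the estimated value is 12000 nM, with an expected range from 3000 nM to 45000 nM.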

Compound 4, half-maximal inhibitory concentration: > 50000 nM
Compound 4: a limit, no number; the forecaster's own chance of this, stated with the estimate: 10%; at least 4.1-fold (0.61 log units) between middle value and limit.
By their numbers in this assay, from the lowest: compounds 2, 1 and 3 (each within the scatter of the next). At a limit, above all of these: compound 4.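

Compound 4 is the only compound shown whose reading in this assay is a limit and not a number: the limit of > 50000 nM in this assay, at which 1 of the 4 values shown sits. The position next to the ring nitrogen, where (tert-butyl)amino takes the place of methyl, therefore responds to change, with an at least 2.2-fold higher number from compound 1 to compound 4 (0.34 log units; beyond the scatter), and the direction is towards weaker inhibition. The two earlier changes stayed within the scatter, with a 1.0-fold lower number from compound 1 to compound 2 (0.01 log units; within the scatter) for chloro on the aromatic carbon and a 1.3-fold higher number from compound 1 to compound 3 (0.13 log units; within the scatter) for the exchange on the amide-type nitrogen, so this methyl position is the only place among those shown where a step goes beyond the scatter.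

From the compounds shown here alone, the limit gives only a floor for the step, so its true size stays unknown, and a single replacement cannot show whether the loss follows the nitrogen attached to the ring, the tert-butyl group or the two together. A plain amino group, a methylamino group or a longer alkyl chain at this position would separate those parts, and the same would hold for any group there that could move the number lower.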